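The compounds below may be only part of what the source reports. "The series", "measured", "known", "first", "only" and "open" are said of these compounds alone.

Compound 3 `COc1ccc(S(=O)(=O)N2CCc3cccc(-c4ccc(F)c(F)c4)c32)cc1` stands at the lowest number of the three in a functional assay on KB cells (Homo sapiens) for inhibition, with a stated time of 72 h; a lower number here means a stronger inhibitor, a higher number a weaker inhibitor: compound 3 gives 45 nM, whereas compound 1 `COc1ccc(S(=O)(=O)N2CCc3cccc(-c4ccc(O)cc4)c32)cc1` gives 129 nM and compound 2 `COc1ccc(S(=O)(=O)N2CCc3cccc(-c4c(F)c(F)c(F)c(F)c4F)c32)cc1` gives 4040 nM. Among the compounds with values here, the only single-point step measured so far, a 2.9-fold lower number from compound 1 to compound 3 (0.46 log units; beyond the scatter), is modest. Compound 4 `COc1ccc(S(=O)(=O)N2CCc3cccc(-c4ccco4)c32)cc1` differs from compound 3 by furan-2-yl in place of 3,4-difluorophenyl on an aromatic carbon. Within the data shown here, no measured step swaps a six-membered aromatic ring of carbon only for a five-membered aromatic ring with one hetero atom, so the bearing of the existing data is indirect; the gap between compound 3 and compound 2 shows how far the number can move at this position. A step beyond the scatter towards a higher number is expected, but of moderate size. Compound 4 is estimated at 150 nM, with a range from 40 nM to 600 nM. The expected step is a 3.3-fold higher number from compound 3 to compound 4 (0.52 log units; beyond the scatter).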

Compound 4, half-maximal inhibitory concentration: 82 nM
Beside the measured number, compound 4's estimate is 1.8-fold (0.26 log units) above it; measured number inside the range.
By their numbers in this assay, from the lowest: compounds 3, 4 and 1 (each within the scatter of the next, the first and the last beyond it); then compound 2.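

A six-membered aromatic ring of carbon only is not needed at this position: furan-2-yl in place of 3,4-difluorophenyl gives a 1.8-fold higher number from compound 3 to compound 4 (0.26 log units; within the scatter) and furan-2-yl in place of 4-hydroxyphenyl gives a 1.6-fold lower number from compound 1 to compound 4 (0.20 log units; within the scatter) with both steps printed as within the scatter. Compound 4 thus cannot be separated from either compound 3 or compound 1, although those two lie beyond the scatter of each other. No supporting data on hand bear on this result.

Still open, going by these compounds, is how a pyridine, a thiophene or a saturated ring such as morpholine would read at this position. On these data alone, whether an amine or a carboxylic acid on the furan ring would shift the number also remains open.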